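Swapping the amide substituent on a shared alkyne-thiazole core

The compounds below may be only part of what the source reports. "The series", "measured", "known", "first", "only" and "open" are said of these compounds alone.

Compound 1 `CC1CCC(C(=O)N2CCc3nc(C#Cc4ccccc4)sc3C2)CC1` carries a 4-methylcyclohexyl on the carbonyl carbon of the shared core. In an assay on HEK293 cells for negative allosteric modulation of metabotropic glutamate receptor 5 (Homo sapiens), read by FLIPR, with a stated time of 1 h (a lower number here means a stronger inhibitor, a higher number a weaker inhibitor), compound 1 gives > 10000 nM, which is a limit of the assay and not a number. Compound 2 `O=C(c1cccc(Cl)c1)N1CCc2nc(C#Cc3ccccc3)sc2C1` has 3-chlorophenyl in that place. In this assay compound 2 gives > 10000 nM, again a limit and not a number. The step that the two limits leave unreadable from compound 1 to compound 2 therefore cannot be read, since both ends sit at the same limit, as the limit of > 10000 nM in this assay, at which 2 of the 2 values shown sit, records.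

Compound 3 `O=C(N1CCC(F)CC1)N1CCc2nc(C#Cc3ccccc3)sc2C1` is the next member. It differs from compound 2 by 4-fluoropiperidin-1-yl in place of 3-chlorophenyl on a carbonyl carbon. Within the data shown here, the only measured step on this carbonyl carbon, from compound 1 to compound 2, gives no readable size, so no measured step bears on this change, and the data give no direction for it. What the two values show is that neither the 4-methylcyclohexyl nor the 3-chlorophenyl compound reaches a number in this assay. Compound 3 is expected to behave the same way, with an estimated 12000 nM (range 3000 nM to 40000 nM). The step from compound 2 to compound 3 is thus expected to be a step that the limit leaves unreadable from compound 2 to compound 3, meaning no readable change.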

Compound 3, half-maximal inhibitory concentration: > 10000 nM
Compound 3: only a limit was reported (the forecaster's own chance of this, stated with the estimate: 75%); the middle value lies beyond the limit too.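

In this assay compound 3 gives > 10000 nM, a limit and not a number. Its steps from compound 1 and from compound 2 cannot be read, because all three compounds sit at the same limit: the limit of > 10000 nM in this assay, at which 3 of the 3 values shown sit.

The compounds shown leave open whether any substituent on this carbonyl carbon gives a readable value in this assay.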